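The source may report more compounds than this note shows. Statements on the series, on what has been measured and on what is new or still open speak of the compounds shown alone.

Of the compounds shown here, three built on one shared core have been tested in a functional assay on MCF7 cells (Homo sapiens) for antiproliferative activity, read by MTT assay, with a stated time of 48 h; on this read-out higher numbers stand for weaker inhibition and lower numbers for stronger inhibition. Compound 1 `COc1cccc(C(=O)Nc2cc3cnc(NCCN(C)C)cc3n(C)c2=O)c1` gives 43300 nM, the highest of the three numbers. Compound 3 `CN(C)CCNc1cc2c(cn1)cc(NC(=O)c1ccccc1)c(=O)n2C` gives 35100 nM, and the step of a 1.2-fold lower number from compound 1 to compound 3 (0.09 log units; within the scatter) stays within the scatter, so these two cannot be told apart on this read-out. Compound 2 `CN(C)CCNc1cc2c(cn1)cc(NC(=O)c1cc3ccccc3s1)c(=O)n2C` gives 12000 nM, and the step of a 3.6-fold lower number from compound 1 to compound 2 (0.56 log units; beyond the scatter) is the one clear movement in the set, with a 2.9-fold higher number from compound 2 to compound 3 (0.47 log units; beyond the scatter) showing the same exchange seen from the other side.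

Compound 4 `COc1ccc(C(=O)Nc2cc3cnc(NCCN(C)C)cc3n(C)c2=O)cc1` differs from compound 1 by 4-methoxyphenyl in place of 3-methoxyphenyl on a carbonyl carbon. Among the compounds with values here, no measured pair moves the methoxy group to another spot on its ring, so the closest guide is a 1.2-fold lower number from compound 1 to compound 3 (0.09 log units; within the scatter), where the methoxy was taken away altogether and the number hardly moved. That suggests the methoxy group contributes little here. The larger steps involving compound 2 concern a different group on the carbonyl carbon and do not bear on this change. The expected step is therefore none beyond the scatter, a 1.1-fold lower number from compound 1 to compound 4 (0.03 log units; within the scatter). Compound 4 is expected to give about 40000 nM, with a plausible range from 15000 nM to 100000 nM.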

Compound 4, half-maximal inhibitory concentration: 37300 nM
Estimate against measurement, compound 4: 1.1-fold (0.03 log units) above; the measured number falls inside the stated range.
By their numbers in this assay, from the lowest: compound 2; then compounds 3, 4 and 1 (each within the scatter of the next).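

Moving the methoxy group, with 4-methoxyphenyl in place of 3-methoxyphenyl on the carbonyl carbon, produces no difference that this assay can resolve (a 1.2-fold lower number from compound 1 to compound 4 (0.06 log units; within the scatter)), so the read-out separates neither placement of the methoxy group on this ring. Compound 4 also cannot be told apart from the compound with a plain phenyl ring (a 1.1-fold higher number from compound 3 to compound 4 (0.03 log units; within the scatter)), while 1-benzothiophen-2-yl remains the only group shown here that stands clearly apart, now also against 4-methoxyphenyl (a 3.1-fold higher number from compound 2 to compound 4 (0.49 log units; beyond the scatter)). No measurement is available to explain why the place of the methoxy group makes no visible difference in these compounds.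

The compounds shown leave open whether a group other than methoxy on the phenyl ring, such as an amine or a carboxylic acid, would shift the number beyond the scatter. They also leave open whether the difference belongs to 1-benzothiophen-2-yl alone or would also appear with another two-ring group such as naphthyl, or with a longer chain placed on the carbonyl carbon.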